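Trading the Nitrophenyl of Compound 3 for a Methylphenyl

The compounds below may be only part of what the source reports. "The series", "measured", "known", "first", "only" and "open" are said of these compounds alone.

Of the compounds shown here, three that share a core have been measured in an assay for inhibition of protein disulfide-isomerase (Homo sapiens), with a stated time of 1 h; a lower number here means a stronger inhibitor, a higher number a weaker inhibitor. Compound 1 `Oc1ccc2ccncc2c1C(c1ccc(F)cc1)N1CCCCC1` gives 10200 nM in this assay. Compound 2 `Oc1ccc2[nH]ccc2c1C(c1ccc(F)cc1)N1CCCCC1` gives 1810 nM in this assay. Compound 3 `Cc1ccnc(NC(c2ccc([N+](=O)[O-])cc2)c2ccc3cccnc3c2O)c1` gives 530 nM in this assay, the lowest of the three numbers; the nearest is that of compound 2, a gap beyond the scatter, and the furthest is that of compound 1, also beyond the scatter. None of these three differ in only one place, so no single step can be read from them.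

Compound 4 `Cc1ccnc(NC(c2ccccc2C)c2ccc3cccnc3c2O)c1` has not yet been measured. Compared with compound 3 it shows one change: 2-methylphenyl in place of 4-nitrophenyl on a saturated chain carbon bound to an aromatic carbon and a nitrogen on an aromatic ring. For the measured compounds named here, no measured pair shows this change, so the direction rests on the structures alone. A moderate rise in the number for compound 4, just beyond the scatter, is expected, as a 2.5-fold higher number from compound 3 to compound 4 (0.39 log units; beyond the scatter). Compound 4 is accordingly estimated at 1300 nM in this assay, with a range from 400 nM to 4500 nM.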

Compound 4, half-maximal inhibitory concentration: > 40000 nM
Compound 4 ended at the assay's limit (the forecaster's own chance of this, stated with the estimate: 5%); middle value at least 30-fold (1.48 log units) from the limit.
By their numbers in this assay, from the lowest: compound 3; then compound 2; then compound 1. At a limit, above all of these: compound 4.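

In this assay compound 4 gives > 40000 nM as a limit of the assay and not as a number. For the compounds shown here, exchanging the 4-nitrophenyl for 2-methylphenyl gives an at least 75-fold higher number from compound 3 to compound 4 (1.87 log units; beyond the scatter) and is the first step in this set that can be read at a single place, showing that the value depends strongly on the group held there. From the compounds shown here alone, the full size of this step stays unknown, and the printed figure is only its lower bound: the limit of > 40000 nM in this assay, at which 1 of the 4 values shown sits.

The compounds shown do not separate the loss of the nitro group from the arrival of the methyl group, or either from its place on the ring. Going by these compounds, how an unsubstituted phenyl or a 4-methoxyphenyl would read on this carbon also stays open.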